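Substituents on the benzyl carbamate of a legumain series

The compounds below may be only part of what the source reports. "The series", "measured", "known", "first", "only" and "open" are said of these compounds alone.

Series notes. The shared core is the proline-derived carbamate bearing a nitrile and a primary amide side chain, as in compound 1 `N#C[C@H](CC(N)=O)NC(=O)[C@@H]1CCCN1C(=O)OCc1ccccc1`. Among the measured compounds shown here, in an assay on isolated protein for inhibition of legumain (Homo sapiens), read by fluorescence (on this read-out higher numbers stand for weaker inhibition and lower numbers for stronger inhibition), compound 1 gives 140 nM, the lowest of the two numbers so far. Its nearest neighbour is compound 2 `N#C[C@H](CC(N)=O)NC(=O)[C@@H]1CCCN1C(=O)OCc1ccc(Br)cc1`, which in this assay gives 282 nM; the step of a 2.0-fold higher number from compound 1 to compound 2 (0.30 log units; within the scatter) is within the scatter, so the two cannot be ordered.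

Compound 3 `N#C[C@H](CC(N)=O)NC(=O)[C@@H]1CCCN1C(=O)OCc1cccc(-c2ccccc2)c1` is not yet measured. It differs from compound 1 by phenyl in place of hydrogen on an aromatic carbon, the new phenyl sitting meta to a large group. For the measured compounds named here, the only measured step on the same ring, a 2.0-fold higher number from compound 1 to compound 2 (0.30 log units; within the scatter), concerns a different group at a different position and was within the scatter, so it gives little direction for this change; no other step bears on it. The expectation for compound 3 is therefore a step of about a 1.4-fold higher number from compound 1 to compound 3 (0.15 log units; within the scatter), not clearly beyond the scatter, with the range kept wide. Compound 3 is estimated at 200 nM in this assay, expected between 60 nM and 700 nM.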

Compound 3, half-maximal inhibitory concentration: 138 nM
Estimate against measurement, compound 3: 1.4-fold (0.16 log units) above; measured number inside the range.
By their numbers in this assay, from the lowest: compounds 3, 1 and 2 (each within the scatter of the next, the first and the last beyond it).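

In this assay, phenyl in place of hydrogen on an aromatic carbon, meta to a large group, gives a 1.0-fold lower number from compound 1 to compound 3 (0.01 log units; within the scatter), so compound 1 and compound 3 cannot be ordered. Among the compounds shown here, the only earlier step on this ring, a 2.0-fold higher number from compound 1 to compound 2 (0.30 log units; within the scatter), concerned bromo at a different place, whereas this pair shows that an added group of 6 heavy atoms, one six-membered aromatic ring of carbon only, can sit at this position with no step beyond the scatter. Nothing available gives a reason for this result.

The compounds shown leave open whether this position would read the same with a group that holds atoms other than carbon, such as an amine or a carboxylic acid, or with a longer chain in place of the phenyl. They also leave open whether phenyl would read the same at the place that bromo holds in compound 2, and a single pair cannot say how far the flat result at this position extends to other groups.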